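This account rests on a few compounds, and the source may have more. Where it says the series, first, only, none or still open, it means among the compounds named here.

Working notes on the series around compound 1 `Oc1ccccc1-c1cc(-c2ccc(F)cc2)cc(-c2ccccc2O)n1`. In a functional assay on DU-145 cells (Homo sapiens) for inhibition (on this read-out lower numbers stand for stronger inhibition and higher numbers for weaker inhibition), compound 1 gives > 50000 nM, which is a limit of the assay and not a number. Compound 2 `Oc1cccc(-c2cc(-c3ccc(F)cc3)cc(-c3ccccc3O)n2)c1` gives a limit, > 50000 nM, in this assay. Compound 3 `Oc1ccccc1-c1cc(-c2cccc(C(F)(F)F)c2)cc(-c2ccccc2O)n1` likewise gives a limit, > 50000 nM, in this assay. The step from compound 1 to compound 2 is a step that the two limits leave unreadable from compound 1 to compound 2, and the step from compound 1 to compound 3 is a step that the two limits leave unreadable from compound 1 to compound 3; all three values sit at the limit of > 50000 nM in this assay, at which 3 of the 3 values shown sit, so no size can be read from either pair. Compound 4 `Oc1ccccc1-c1cc(-c2ccc(OC(F)(F)F)cc2)cc(-c2ccccc2O)n1` differs from compound 1 by trifluoromethoxy in place of fluoro on an aromatic carbon, para to a large group. Going by the values given here, the one measured step at the same place, the one from compound 1 to compound 3, carries no readable size, and compound 1 itself offers only a limit. The step from compound 1 to compound 4 in this assay is therefore expected to be a number no higher from compound 1 to compound 4 (the limit leaves the size open), with no direction readable beyond the scatter. Compound 4 is expected at 50000 nM, in the range 20000 nM to 150000 nM, most likely reported again as a limit.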

Compound 4, half-maximal inhibitory concentration: 20300 nM
Compound 4: the middle estimate sits 2.5-fold (0.39 log units) above what was measured; low and high end bracket the measured number.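

In this assay, going by these compounds alone, trifluoromethoxy in place of fluoro, on an aromatic carbon para to a large group, gives an at least 2.4-fold lower number from compound 1 to compound 4 (0.39 log units; beyond the scatter), the first step that can be read. Within the data shown here, this shows that a change at this place can move the read-out beyond the scatter, which the earlier steps to compound 2 and compound 3 could not show, as neither of them can be read. Compound 4 is the only compound shown with a number, while the other three stay at the limit: the limit of > 50000 nM in this assay, at which 3 of the 4 values shown sit.

From the compounds shown here alone, what an amine, a carboxylic acid or a longer alkoxy chain at this place would do remains open. Going by these compounds, the full size of the step also remains open, as the value for compound 1 is a limit and not a number.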